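Stripping Both Halogens from the Benzyl Group of Compound 3

The compounds below may be only part of what the source reports. "The series", "measured", "known", "first", "only" and "open" are said of these compounds alone.

Measured so far:
compound 1, `COc1ccc(N2C(=O)N(Cc3c(F)cc(F)cc3F)c3ccccc3S2(=O)=O)cc1OC`: 2 nM
compound 2, `COc1ccc(N2C(=O)N(Cc3ccccc3F)c3ccccc3S2(=O)=O)cc1OC`: 6.31 nM
compound 3, `COc1ccc(N2C(=O)N(Cc3c(F)cccc3Cl)c3ccccc3S2(=O)=O)cc1OC`: 0.794 nM

In an assay on HEK293 cells for displacement of a labelled ligand from Orexin receptor type 2 (Homo sapiens), read by scintillation counting, with a stated time of 90 min (a higher number here means a weaker inhibitor, a lower number a stronger inhibitor), compound 3 gives 0.794 nM and stands lowest of the three; the steps of a 2.5-fold lower number from compound 1 to compound 3 (0.40 log units; beyond the scatter) and a 7.9-fold lower number from compound 2 to compound 3 (0.90 log units; beyond the scatter) both lead down to it. Compound 4, `COc1ccc(N2C(=O)N(Cc3ccccc3)c3ccccc3S2(=O)=O)cc1OC`, carries the change (phenyl in place of 2-chloro-6-fluorophenyl on a saturated chain carbon bound to an amide-type nitrogen in a ring). The step of a 7.9-fold lower number from compound 2 to compound 3 (0.90 log units; beyond the scatter) bears directly. It shows the chloro alone, and undoing it points to a higher number. The step of a 3.2-fold higher number from compound 1 to compound 2 (0.50 log units; beyond the scatter) shows that fewer fluorines also raised the number. Going by the values given here, no measured pair shows the loss of the last fluorine. The number for compound 4 is therefore expected to rise beyond the scatter, by about a 19-fold higher number from compound 3 to compound 4 (1.28 log units; beyond the scatter). Compound 4 is estimated at 15 nM, within 4 nM to 60 nM.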

Compound 4, inhibition constant: 79.4 nM
Estimate against measurement, compound 4: 5.3-fold (0.72 log units) below; the whole stated range lies below it.
By their numbers in this assay, from the lowest: compound 3; then compound 1; then compound 2; then compound 4.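

In this assay, even the one remaining fluorine counts at this position: its loss gives a 13-fold higher number from compound 2 to compound 4 (1.10 log units; beyond the scatter), so the unsubstituted phenyl is not a neutral baseline. Measured against the plain benzyl, the other two compounds show a 40-fold higher number from compound 1 to compound 4 (1.60 log units; beyond the scatter) and a 100-fold higher number from compound 3 to compound 4 (2.00 log units; beyond the scatter), and all three halogen patterns give lower numbers than compound 4. Nothing here explains why these halogens matter. Still open, on these data alone, is whether a bromo or a methoxy on the ring would do the same, and whether a chloro without any fluoro would suffice.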